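A Thiourea in Place of a Cyanoguanidine

The compounds below may be only part of what the source reports. "The series", "measured", "known", "first", "only" and "open" are said of these compounds alone.

In a functional assay on the whole organism (stomach) with Rattus norvegicus as the target (a lower number here means that less compound is needed, a higher number that more compound is needed for the effect), compound 2, `CN(C)/C(=N/CCCCn1nc(-c2ccccc2)ccc1=O)NC#N`, gives 30.3 mg/kg, the only numeric result among the compounds measured here. Compound 1, `C/N=C(/NC#N)NCCCn1nc(-c2ccccc2)ccc1=O`, reaches only a limit in this assay, recorded as > 100 mg/kg, a result that is the limit of > 100 mg/kg in this assay, at which 1 of the 2 values shown sits. Compound 2 therefore stands alone as the measured reference point.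

Compound 3, `C/N=C(\S)NCCCCCn1nc(-c2ccccc2)ccc1=O`, has not yet been tested. It differs from compound 2 by a group of 6 heavy atoms (3 carbon, 2 nitrogen, 1 sulfur; no ring) in place of a group of 8 heavy atoms (4 carbon, 4 nitrogen; no ring), on a saturated chain carbon, four bonds along the chain from an aromatic nitrogen. For the measured compounds named here, no measured step between comparable compounds is available, so the size of this change can only be expected rather than read off from earlier data. The remainder of the structure is shared by both compounds. The account therefore expects a step no larger than the usual scatter, a 1.3-fold higher number from compound 2 to compound 3 (0.12 log units; within the scatter), in this assay. Compound 3 is accordingly expected to give an estimated 40 mg/kg, within a range from 10 mg/kg to 150 mg/kg.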

Compound 3, dose for half-maximal effect: 35.3 mg/kg
Compound 3: middle estimate off by 1.1-fold (0.05 log units), on the high side; low and high end bracket the measured number.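

In this assay the exchange gives a 1.2-fold higher number from compound 2 to compound 3 (0.07 log units; within the scatter), so the group of 6 heavy atoms (3 carbon, 2 nitrogen, 1 sulfur; no ring) and the group of 8 heavy atoms (4 carbon, 4 nitrogen; no ring) cannot be told apart at this place on a saturated chain carbon. For the compounds shown here, the other step, an at least 2.8-fold lower number from compound 1 to compound 3 (0.45 log units; beyond the scatter), is the first to lie beyond the scatter. The value of compound 1 is a limit and not a number, so this step gives only a minimum size: the limit of > 100 mg/kg in this assay, at which 1 of the 3 values shown sits.

What the compounds shown leave open is how much of that step belongs to the chain and how much to the group at its end. They also leave open whether a urea or a simple amine at the end of the chain would serve in the same way.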